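The source may hold more compounds than are shown below. What is called first, only, known or untested is meant among the compounds shown, and "the series" means these compounds.

In a functional assay on HCT-116 cells (Homo sapiens) for antiproliferative activity, read by sulforhodamine B assay, with a stated time of 72 h (on this read-out higher numbers stand for weaker inhibition and lower numbers for stronger inhibition), two compounds of a shared core have been measured. Compound 1 `COc1ncc(-c2ccc3ncc(NC(=O)C4CCCCC4)c(OC)c3c2)cc1NS(=O)(=O)c1ccc(F)cc1F` gives 4610 nM in this assay, and compound 2 `CCNc1cnc2ccc(-c3cnc(OC)c(NS(=O)(=O)c4ccc(F)cc4F)c3)cc2c1OC` gives 1850 nM. Between them lies a single step, a 2.5-fold lower number from compound 1 to compound 2 (0.40 log units; beyond the scatter), so compound 2 stands with the lowest of the two numbers, and compound 1 is its nearest neighbour. Compound 3 `COc1ncc(-c2ccc3ncc(NC(=O)CN4CCN(C)CC4)c(OC)c3c2)cc1NS(=O)(=O)c1ccc(F)cc1F` has not yet been measured in this assay. It differs from compound 2 in one place: ((4-methylpiperazin-1-yl)methyl)carbonyl in place of ethyl on a nitrogen on an aromatic ring. Among the measured compounds shown here, the one measured step that bears on this is the step from compound 1 to compound 2, in which an acyl group on the same ring nitrogen gave way to ethyl and the number fell modestly. The change to compound 3 goes the other way, bringing an acyl group back onto that nitrogen, though a different one from the cyclohexylcarbonyl of compound 1. It is therefore expected that the number will rise again, by a modest step of a 1.9-fold higher number from compound 2 to compound 3 (0.28 log units; within the scatter), toward the region of compound 1. For compound 3 the estimate in this assay is 3500 nM, with a likely range from 1400 nM to 9000 nM.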

Compound 3, half-maximal inhibitory concentration: 1540 nM
The estimate for compound 3 lay 2.3-fold (0.36 log units) above the measured number, and the stated range covers the measured number.
By their numbers in this assay, from the lowest: compounds 3 and 2 (each within the scatter of the next); then compound 1.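

In this assay, ((4-methylpiperazin-1-yl)methyl)carbonyl, with 10 heavy atoms, takes the place of ethyl, with 2, on the nitrogen on the aromatic ring, and the result is a 1.2-fold lower number from compound 2 to compound 3 (0.08 log units; within the scatter); compounds 2 and 3 therefore cannot be told apart here, and a carbonyl on this nitrogen does not by itself bring the number of compound 1. With the carbonyl kept, the group on its carbon makes a readable difference: (4-methylpiperazin-1-yl)methyl in place of cyclohexyl gives a 3.0-fold lower number from compound 1 to compound 3 (0.48 log units; beyond the scatter), so the earlier step from compound 1 to compound 2 cannot be read as a simple contrast between an acyl group and an alkyl group. No measurement is available that bears on the origin of this difference.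

The compounds shown leave open whether a morpholine or a dimethylamino group on the same methyl carbon would read like compound 3 or like compound 1. They also leave open how the free amine, with neither ethyl nor an acyl group on that nitrogen, would compare with compounds 2 and 3.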